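Cinnamate esters of a trimethoxy cinnamyl alcohol: an open question

This account rests on a few compounds, and the source may have more. Where it says the series, first, only, none or still open, it means among the compounds named here.

The study covers three cinnamate esters that share a trimethoxy cinnamyl alcohol part and differ in the aromatic ring on the acid side. Compound 1 `COc1cc(OC)c(OC)cc1/C=C/COC(=O)/C=C/c1ccc(OC)c(OC)c1OC` carries a trimethoxyphenyl ring there, and in a functional assay on the whole organism (strain Kunming) with Mus musculus as the target, with a stated time of 0.5 h, at a dose of 100 mg/kg by the intraperitoneal route (a lower number here means a stronger effect, a higher number a weaker effect of the compound at the dose given), compound 1 gives 100%. Compound 2 `COc1cc(OC)c(OC)cc1/C=C/COC(=O)/C=C/c1ccc(F)cc1` carries a 4-fluorophenyl ring instead, and in this assay compound 2 gives 100%. On these numbers compound 2 stands level with compound 1: the two values are the same at the digits printed, so nothing separates them within the scatter.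

Compound 3 `COc1cccc(/C=C/C(=O)OC/C=C/c2cc(OC)c(OC)cc2OC)c1` has not yet been measured. It differs from compound 2 in one place: 3-methoxyphenyl in place of 4-fluorophenyl on a double-bonded chain carbon bound to a double-bonded chain carbon. Going by the values given here, both measured rings, one heavily substituted and one bearing a single fluorine, reached the same reading, and nothing among the measured compounds points to a direction for this exchange. The step from compound 2 to compound 3 in this assay is therefore expected to be small, a number 5 percentage points lower from compound 2 to compound 3 (within the scatter), not beyond the scatter. Compound 3 is expected to give about 95%, within a range from 70% to 100%.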

Compound 3, a percentage reported as activity, at one dose (the size of the read-out at that dose, not a potency): 100%
Estimate against measurement, compound 3: 5 percentage points below, within the range that was stated.
By their numbers in this assay, from the lowest: compounds 1, 2 and 3 (each within the scatter of the next).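

In this assay, going by these compounds alone, exchanging 4-fluorophenyl for 3-methoxyphenyl on a double-bonded chain carbon bound to a double-bonded chain carbon gives no change at the digits printed from compound 2 to compound 3 (within the scatter), and this is the first step that can be read at this position. The entering group brings an oxygen and a hydrogen-bond acceptor that the leaving group lacks, yet these differences leave no trace in the reading at this dose, and with compound 3 three different rings on the acid side now print the same value. Nothing available explains why the reading stays the same across these rings.

On these data alone, it remains open whether a ring carrying an amine or a carboxylic acid at this position would separate from the three compounds in this assay. It is equally open whether a longer chain between the ring and the ester carbonyl would change the reading, since every compound shown keeps the same chain and the same alcohol part.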